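Hydroxy versus methoxy on a pyrazole-amide series

A few compounds are considered here, and "the series" means these few. Any claim that something is new, unique, unknown or untested is made for them only; others in the source may bear on it.

Measured so far:
compound 1 `O=C(Nc1cccc(-n2cc(-c3ccncc3)c(-c3cc(O)cc(Cl)c3)n2)c1)Nc1ccc(Cl)c(Cl)c1` — 4.08%
compound 2 `COc1cc(Cl)cc(-c2nn(-c3cccc(NC(=O)c4cccc(C(F)(F)F)c4)c3)cc2-c2ccncc2)c1` — 53.9%
compound 3 `O=C(Nc1cccc(-n2cc(-c3ccncc3)c(-c3cc(O)cc(Cl)c3)n2)c1)c1cc(C(F)(F)F)cc(C(F)(F)F)c1` — 52.7%

In a functional assay on SNB-75 cells (Homo sapiens) for inhibition, read by sulforhodamine B assay, with a stated time of 48 h, tested at 10 uM (a higher number here means a weaker effect of the compound at the concentration tested, a lower number a stronger effect), compound 3 gives 52.7%, the second highest of the three numbers. Its nearest neighbour is compound 2, which gives 53.9%, a gap within the scatter, so the two cannot be told apart. Among the measured compounds shown here, compound 1, the urea, gives 4.08%, a gap to compound 3 beyond the scatter; the urea is the only compound here with a low number.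

Compound 4 `COc1cc(Cl)cc(-c2nn(-c3cccc(NC(=O)c4cc(C(F)(F)F)cc(C(F)(F)F)c4)c3)cc2-c2ccncc2)c1` is not yet measured. It differs from compound 3 as follows: methyl in place of hydrogen on an oxygen on an aromatic ring. For the measured compounds named here, no pair in the measured set carries this single change in isolation, so the size of the step is not known from data. What can be said is that compound 2 and compound 3, which differ both at this oxygen and in the amide substitution, give numbers within the scatter of each other.

The step from compound 3 to compound 4 is therefore expected to be small, a number 0.7 percentage points lower from compound 3 to compound 4 (within the scatter), likely not beyond the scatter in either direction. Compound 4 is estimated at 52%, with a range from 32% to 72%, resting on the closeness of compound 2 and compound 3.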

Compound 4, a percentage reported as activity, at one concentration (the size of the read-out at that concentration, not a potency): 60.8%
Compound 4: middle estimate off by 8.8 percentage points, on the low side; measured number inside the range.
By their numbers in this assay, from the lowest: compound 1; then compounds 3, 2 and 4 (each within the scatter of the next).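

In this assay, the change from hydroxy to methoxy, which turns 3-chloro-5-hydroxyphenyl into 3-chloro-5-methoxyphenyl, can now be read in isolation: a number 8.1 percentage points higher from compound 3 to compound 4 (within the scatter). At this oxygen on an aromatic ring, methyl in place of hydrogen therefore gives no step that can be told from scatter in this pair, and the free hydroxy is not shown to matter here. The second single change, trifluoromethyl in place of hydrogen on an aromatic carbon of the amide side, is equally unresolved, with a number 6.9 percentage points higher from compound 2 to compound 4 (within the scatter), and no measurement is available that bears on either result.

The compounds shown leave open whether the change from hydroxy to methoxy would stay as small in the urea, compound 1, which gives 4.08%, since that compound has no partner differing from it only at this oxygen. They also leave open how a longer chain on this oxygen, such as ethoxy, or an amine in place of the hydroxy would read in this assay.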